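Aryl exchange on the ether oxygen

A few compounds are considered here, and "the series" means these few. Any claim that something is new, unique, unknown or untested is made for them only; others in the source may bear on it.

Going by the values given here, in a functional assay on HL-60 cells (Homo sapiens) for antiproliferative activity, read by MTT assay, with a stated time of 72 h (on this read-out lower numbers stand for stronger inhibition and higher numbers for weaker inhibition), compound 1 `NC1=NC2(CCOCC2)N(OCCCOc2ccccc2)C(N)=N1` gives 2460 nM and compound 2 `NC1=NC2(CCOCC2)N(OCCCOc2cc(Cl)c(Cl)cc2Cl)C(N)=N1` gives 2360 nM, so compound 2 stands level with the only other measured compound. Compound 3 `NC1=NC2(CCOCC2)N(OCCCOc2ccccc2Br)C(N)=N1` carries 2-bromophenyl in place of 2,4,5-trichlorophenyl on an oxygen on a saturated carbon. Among the compounds with values here, the single measured step, a 1.0-fold lower number from compound 1 to compound 2 (0.02 log units; within the scatter), exchanged the aryl group at this same place. No change beyond the scatter is therefore expected in this assay. The expected step is a 1.0-fold lower number from compound 2 to compound 3 (0.01 log units; within the scatter). For compound 3 the estimate is 2300 nM, with an expected range of 1000 nM to 5500 nM.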

Compound 3, half-maximal inhibitory concentration: 610 nM
Compound 3: the middle estimate sits 3.8-fold (0.58 log units) above what was measured; the whole stated range lies above it.
By their numbers in this assay, from the lowest: compound 3; then compounds 2 and 1 (each within the scatter of the next).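

Aryl exchange on this oxygen does change the number in this assay (a 3.9-fold lower number from compound 2 to compound 3 (0.59 log units; beyond the scatter)), whereas the earlier exchange of phenyl for 2,4,5-trichlorophenyl stayed within the scatter. A single bromo in place of hydrogen on an aromatic carbon also moves the number beyond the scatter (a 4.0-fold lower number from compound 1 to compound 3 (0.61 log units; beyond the scatter)), yet compound 2, with three chlorines, stays level with compound 1, so halogen on the ring does not by itself lower the number. Nothing at hand accounts for this difference. Still open, from the compounds shown here alone, is whether a single chloro or a methoxy on the phenyl would match the 2-bromophenyl group, and how a longer chain on the oxygen would read.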